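The source may hold more compounds than are shown below. What is called first, only, known or untested is meant among the compounds shown, and "the series" means these compounds.

Measured in a functional assay on MDA-MB-231 cells (Homo sapiens) for inhibition, read by CCK-8 assay, with a stated time of 48 h; a higher number here means a weaker inhibitor of growth, a lower number a stronger inhibitor of growth:
- compound 1 `Cc1ccccc1Nc1nc(Nc2ccc(N3CCN(C)CC3)cn2)ncc1Cl` gives 7470 nM
- compound 2 `COc1cccc(CNc2nc(Nc3ccc(N4CCN(C)CC4)cn3)ncc2Cl)c1` gives 20300 nM
- compound 3 `Cc1ccc(Nc2nc(Nc3ccc(N4CCN(C)CC4)cn3)ncc2Cl)cc1` gives 4030 nM

In this assay, compound 3 cannot be separated from compound 1, since a 1.9-fold lower number from compound 1 to compound 3 (0.27 log units; within the scatter). It stands clearly apart from compound 2, with a 5.0-fold lower number from compound 2 to compound 3 (0.70 log units; beyond the scatter). Compound 4 `CCc1ccc(Nc2nc(Nc3ccc(N4CCN(C)CC4)cn3)ncc2Cl)cc1` differs from compound 3 by one small change, methyl in place of hydrogen on a saturated chain carbon bound to an aromatic carbon, which turns 4-methylphenyl into 4-ethylphenyl.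

Among the compounds with values here, no measured step tests this change directly, so the evidence is indirect. Exchanging 2-methylphenyl for 4-methylphenyl gave a 1.9-fold lower number from compound 1 to compound 3 (0.27 log units; within the scatter), so that exchange did not move the number beyond the scatter. Within the data shown here, the only steps beyond it are modest and involve the much larger exchange with 3-methoxybenzyl, namely a 2.7-fold higher number from compound 1 to compound 2 (0.43 log units; beyond the scatter) and a 5.0-fold lower number from compound 2 to compound 3 (0.70 log units; beyond the scatter). Three compounds are a thin basis, but an extension from 4-methylphenyl to 4-ethylphenyl is expected to produce no step beyond the scatter, and no direction is favoured. The expected step is a 1.1-fold lower number from compound 3 to compound 4 (0.03 log units; within the scatter). For compound 4 the estimated value is 3800 nM, with an expected range of 1700 nM to 8500 nM.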

Compound 4, concentration for 50% growth inhibition: 5560 nM
The estimate for compound 4 lay 1.5-fold (0.17 log units) below the measured number, and the stated range covers the measured number.
By their numbers in this assay, from the lowest: compounds 3, 4 and 1 (each within the scatter of the next); then compound 2.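

In this assay, within the data shown here, the step from 4-methylphenyl to 4-ethylphenyl gives the first direct reading at this position (a 1.4-fold higher number from compound 3 to compound 4 (0.14 log units; within the scatter)): adding methyl on a saturated chain carbon bound to an aromatic carbon leaves compound 4 inseparable from compound 3. Compound 4 also cannot be separated from its 2-methylphenyl counterpart (a 1.3-fold lower number from compound 1 to compound 4 (0.13 log units; within the scatter)), yet it stands apart from the 3-methoxybenzyl compound (a 3.7-fold lower number from compound 2 to compound 4 (0.56 log units; beyond the scatter)), so the three compounds with a directly attached methyl- or ethyl-substituted phenyl group form one group, with compound 2 outside it. Nothing in the data shown explains why this small extension stays within the scatter.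

Going by these compounds, it remains open whether a longer chain such as propyl in place of the ethyl, or an amine or a carboxylic acid at this place, would also stay within the scatter or would move the number clearly in either direction. Among these compounds, since a single added methyl is the only change tested here, the limit of what this position accepts is also unknown.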